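This account rests on a few compounds, and the source may have more. Where it says the series, first, only, none or still open, it means among the compounds named here.

Compound 1 `CC(C)(C)c1ccc(C(=O)N2CCC3(CC2)C(=O)N(CC(=O)N2CCCCC2CCO)CN3c2ccccc2)cc1` gives 6100 nM in an assay on HEK293 cells for displacement of a labelled ligand from NPC1-like intracellular cholesterol transporter 1 (Homo sapiens); a higher number here means a weaker inhibitor, a lower number a stronger inhibitor.
Compound 2 `CC1CCCN(C(=O)CN2CN(c3ccccc3)C3(CCN(C(=O)c4ccc(C(C)(C)C)cc4)CC3)C2=O)C1` gives 12000 nM.
Compound 3 `CCOC(=O)C1CCN(C(=O)CN2CN(c3ccccc3)C3(CCN(C(=O)c4ccc(C(C)(C)C)cc4)CC3)C2=O)CC1` gives 3100 nM.

Among these three, compound 3 has the lowest number in this assay. For the measured compounds named here, its nearest neighbour is reached by a 2.0-fold lower number from compound 1 to compound 3 (0.29 log units; within the scatter), a step inside the scatter, while a 3.9-fold lower number from compound 2 to compound 3 (0.59 log units; beyond the scatter) is the only step beyond it. Compound 4 `CCOC(=O)C1CCCN(C(=O)CN2CN(c3ccccc3)C3(CCN(C(=O)c4ccc(C(C)(C)C)cc4)CC3)C2=O)C1` is built from compound 3 by a rearrangement: 3-(ethoxycarbonyl)piperidin-1-yl in place of 4-(ethoxycarbonyl)piperidin-1-yl on a carbonyl carbon. Every measured step in this set alters the group on the same carbonyl carbon, so all three bear on this change, but none of them moves a substituent around the piperidine ring alone. The steps of a 2.0-fold higher number from compound 1 to compound 2 (0.29 log units; within the scatter) and a 2.0-fold lower number from compound 1 to compound 3 (0.29 log units; within the scatter) are small, and a 3.9-fold lower number from compound 2 to compound 3 (0.59 log units; beyond the scatter) is modest. Going by the values given here, compound 2, the one compound carrying a group in the 3-position of the piperidine, gives 12000 nM, the highest number here, which hints weakly at a higher number for compound 4. Compound 4 is therefore expected to give roughly 4500 nM, between 2000 nM and 11000 nM, a change of a 1.5-fold higher number from compound 3 to compound 4 (0.16 log units; within the scatter) that is expected to stay near the scatter.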

Compound 4, half-maximal inhibitory concentration: 8200 nM
Estimate against measurement, compound 4: 1.8-fold (0.26 log units) below, within the range that was stated.
By their numbers in this assay, from the lowest: compounds 3, 1, 4 and 2 (each within the scatter of the next, the first and the last beyond it).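

In this assay, the ethoxycarbonyl group changes only its place on the piperidine, with the same atoms throughout, and this alone gives a 2.6-fold higher number from compound 3 to compound 4 (0.42 log units; beyond the scatter), so 4-(ethoxycarbonyl)piperidin-1-yl and 3-(ethoxycarbonyl)piperidin-1-yl are not interchangeable on this carbonyl carbon. The exchange of methyl for ethoxycarbonyl, at a 1.5-fold lower number from compound 2 to compound 4 (0.17 log units; within the scatter), stays within the scatter, as does the exchange of the whole group at a 1.3-fold higher number from compound 1 to compound 4 (0.13 log units; within the scatter), so compound 4 cannot be told apart from compound 2 or compound 1. Nothing available here explains why the place of the group matters.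

As far as these compounds go, it remains open whether a carboxylic acid or a primary amide in place of ethoxycarbonyl would show the same difference between the two ring places. From the compounds shown here alone, it is also open whether a methyl group would show that difference.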